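Shifting two halogens on the terminal phenyl ring

The source may report more compounds than this note shows. Statements on the series, on what has been measured and on what is new or still open speak of the compounds shown alone.

Three compounds share one core and differ at the far end of the molecule. Compound 1 `COc1cc2c(Oc3ccc(NC(=O)N/N=C/c4ccncc4)cc3F)ccnc2cc1OCCCN1CCCCC1` gives 980 nM in a functional assay on MKN-45 cells (Homo sapiens) for cytotoxicity, read by MTT assay, with a stated time of 72 h; a higher number here means a weaker inhibitor, a lower number a stronger inhibitor. Compound 2 `COc1cc2c(Oc3ccc(NC(=S)N/N=C/c4ccccc4)cc3F)ccnc2cc1OCCCN1CCCCC1` gives 710 nM, and the step of a 1.4-fold lower number from compound 1 to compound 2 (0.14 log units; within the scatter) is small. Compound 3 `COc1cc2c(Oc3ccc(/C=N/NC(=O)Nc4ccc(F)c(F)c4)cc3F)ccnc2cc1OCCCN1CCCCC1` gives 320 nM, the lowest of the three numbers; its gap to compound 2 and its gap to compound 1 are both beyond the scatter, so compound 3 is the strongest inhibitor measured here.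

Compound 4 `COc1cc2c(Oc3ccc(/C=N/NC(=O)Nc4ccc(F)cc4Br)cc3F)ccnc2cc1OCCCN1CCCCC1` takes the same core and changes only the terminal ring: 2-bromo-4-fluorophenyl in place of 3,4-difluorophenyl on an amide-type nitrogen. For the measured compounds named here, no measured step concerns this kind of change; the single step from compound 1 to compound 2 alters a different part of the molecule, and there is nothing to show how swapping halogens on the terminal phenyl ring shifts the number. The expectation therefore rests on compound 3 alone and is expected to be a step of a 1.3-fold higher number from compound 3 to compound 4 (0.10 log units; within the scatter), not beyond the scatter. Compound 4 is estimated at 400 nM, in a range from 150 nM to 1200 nM.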

Compound 4, half-maximal inhibitory concentration: 140 nM
Beside the measured number, compound 4's estimate is 2.9-fold (0.46 log units) above it, and the stated range ends above it.
By their numbers in this assay, from the lowest: compound 4; then compound 3; then compounds 2 and 1 (each within the scatter of the next).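

The terminal ring on the amide-type nitrogen proves to be a place where the number can move: 2-bromo-4-fluorophenyl in place of 3,4-difluorophenyl gives a 2.3-fold lower number from compound 3 to compound 4 (0.36 log units; beyond the scatter) in this assay and makes compound 4 the lowest of the four. For the compounds shown here, the earlier compounds offered no step at this position, so this is the first measured swap of halogens on that ring, with the six-membered ring and its count of eight heavy atoms unchanged. Nothing measured here explains why the number falls.

The compounds shown leave open whether the shift follows from the bromine that enters or from the fluorine that leaves. They also leave open how the number would respond to a chlorine, a methoxy group or an amine on this ring.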